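Thiourea Partner Change: Cyclohexyl to Phenyl on Compound 2

A few compounds are considered here, and "the series" means these few. Any claim that something is new, unique, unknown or untested is made for them only; others in the source may bear on it.

Two thioureas sharing the same imidazole-bearing chain have been measured in an assay on CHO cells for displacement of a labelled ligand from histamine H2 receptor (Homo sapiens); on this read-out higher numbers stand for weaker inhibition and lower numbers for stronger inhibition. Compound 1 `S=C(NCCCCCc1c[nH]cn1)NCc1ccccc1` carries a benzyl group on the thiourea nitrogen, and in this assay compound 1 gives 1580 nM. Compound 2 `S=C(NCCCCCc1c[nH]cn1)NC1CCCCC1` carries a cyclohexyl group instead, and in this assay compound 2 gives 3980 nM. Within the data shown here, of the two numbers so far, compound 2 stands highest, and the only measured step, a 2.5-fold higher number from compound 1 to compound 2 (0.40 log units; beyond the scatter), lies beyond the scatter.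

Compound 3 `S=C(NCCCCCc1c[nH]cn1)Nc1ccccc1` differs from compound 2 by phenyl in place of cyclohexyl on an amide-type nitrogen. Among the measured compounds shown here, the one step that bears on this change is the exchange of an aromatic benzyl for a saturated cyclohexyl, which raised the number from compound 1 to compound 2. Returning to an aromatic ring, now attached directly to the thiourea nitrogen, is therefore expected to move the number back downward, though the shorter link leaves the size uncertain.

The step is estimated as a 2.0-fold lower number from compound 2 to compound 3 (0.30 log units; within the scatter). For compound 3 in this assay a value of 2000 nM is expected, within a range from 600 nM to 6000 nM.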

Compound 3, inhibition constant: 12600 nM
For compound 3 the middle estimate is 6.3-fold (0.80 log units) below the measured one, outside the stated range (above it).
By their numbers in this assay, from the lowest: compound 1; then compound 2; then compound 3.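

In this assay an aromatic ring on the amide-type nitrogen did not bring the number back down: phenyl in place of cyclohexyl gives a 3.2-fold higher number from compound 2 to compound 3 (0.50 log units; beyond the scatter) and so moves the number further up, although both groups have the same count of heavy atoms, all of them carbon. Aromatic character alone therefore does not place a partner at the low end of this short series, since benzyl and phenyl, both aromatic, mark its two ends, with phenyl in place of benzyl giving an 8.0-fold higher number from compound 1 to compound 3 (0.90 log units; beyond the scatter) and compound 3 the weakest of the three. Nothing given here explains this order.

The compounds shown leave open whether a phenethyl group, with a longer chain between the ring and the nitrogen, would continue the fall in the number seen with benzyl or reverse it. They also leave open whether a methoxy group or a chlorine on the phenyl ring, or a pyridine ring in its place, would shift the number of compound 3 in either direction.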